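The source may hold more compounds than are shown below. What is called first, only, known or untested is meant among the compounds shown, and "the series" means these compounds.

Compound 1 `CC(C)N1CC(=O)N=C1NC(=N)Nc1ccc(Cl)c(Cl)c1`: > 1 h
Compound 2 `CC(C)N1CC(=O)N=C1N/C(=N\C(C)(C)C)Nc1ccc(Cl)c(Cl)c1`: 0.662 h

In an in vivo ADME assay on the whole organism for metabolic stability, with Homo sapiens as the target, read by LC-MS, at a dose of 160 mg/kg by the oral route (a higher number here means that the compound lasts longer, a lower number that the compound disappears faster), compound 1 gives > 1 h, which is a limit of the assay and not a number. That limit is all that is known of compound 1, and it accounts for one of the two results: the limit of > 1 h in this assay, at which 1 of the 2 values shown sits. Compound 2 gives a measured number, 0.662 h.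

Compound 3 `CC(C)(C)N1CC(=O)N=C1NC(=N)Nc1ccc(Cl)c(Cl)c1` is compound 1 with one change, isopropyl to tert-butyl: methyl in place of hydrogen on a saturated chain carbon bound to an amine nitrogen in a ring and two saturated chain carbons. Going by the values given here, no measured pair shows such a change, so no change beyond the scatter is expected in this assay, in either direction. The expected step is a step that the limit leaves unreadable from compound 1 to compound 3. For compound 3 the estimated half-life is 1.5 h, with an expected range from 0.7 h to 4 h.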

Compound 3, half-life: > 1 h
Compound 3 was reported as a limit; the forecaster's own chance of this, stated with the estimate: 35%; the middle value does not contradict the limit.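

No step can be read from compound 1 to compound 3 in this assay, since both results are limits of the assay and not numbers: the limit of > 1 h in this assay, at which 2 of the 3 values shown sit.

The compounds shown leave open what the half-lives of compound 1 and compound 3 actually are, and whether isopropyl to tert-butyl changes them at all.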